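The source may hold more compounds than are shown below. What is called first, only, known or untested is meant among the compounds shown, and "the series" means these compounds.

The series shares one core. Compound 1 `CC(=O)N1CCC[C@H]1C(=O)N1CCC(NS(=O)(=O)c2cc(S(=O)(=O)c3ccccc3)ccc2C(F)(F)F)CC1` gives 250 nM in a functional assay on U2OS cells for antagonist activity at proto-oncogene Wnt-3 (Homo sapiens), read by a luciferase reporter, with a stated time of 18 h; a lower number here means that less compound is needed, a higher number that more compound is needed for the effect. Compound 2 `CC(C)(C)C(=O)N1CCC[C@H]1C(=O)N1CCC(NS(=O)(=O)c2cc(S(=O)(=O)c3ccccc3)ccc2C(F)(F)F)CC1` gives 270 nM in this assay, and compound 3 `CN(C)CC(=O)N1CCC[C@H]1C(=O)N1CCC(NS(=O)(=O)c2cc(S(=O)(=O)c3ccccc3)ccc2C(F)(F)F)CC1` gives 310 nM. Compound 3 stands with the highest of the three numbers, yet its steps of a 1.1-fold higher number from compound 2 to compound 3 (0.06 log units; within the scatter) and a 1.2-fold higher number from compound 1 to compound 3 (0.09 log units; within the scatter) both sit within the scatter, as does a 1.1-fold higher number from compound 1 to compound 2 (0.03 log units; within the scatter). The three groups tried on this carbonyl carbon leave this assay essentially level.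

Compound 4 `CN(C)c1ccc(C(=O)N2CCC[C@H]2C(=O)N2CCC(NS(=O)(=O)c3cc(S(=O)(=O)c4ccccc4)ccc3C(F)(F)F)CC2)cc1` carries the change (4-(dimethylamino)phenyl in place of (dimethylamino)methyl on a carbonyl carbon). For the measured compounds named here, no measured step brings a ring to this position; the three steps that bear on it, a 1.1-fold higher number from compound 1 to compound 2 (0.03 log units; within the scatter), a 1.2-fold higher number from compound 1 to compound 3 (0.09 log units; within the scatter) and a 1.1-fold higher number from compound 2 to compound 3 (0.06 log units; within the scatter), all lie within the scatter, so no step beyond the scatter is expected for a 1.0-fold lower number from compound 3 to compound 4 (0.01 log units; within the scatter), though the range is kept wide because the ring is untested here. Compound 4 is therefore estimated at 300 nM in this assay, expected between 110 nM and 800 nM.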

Compound 4, half-maximal effective concentration: 830 nM
Compound 4: the middle estimate sits 2.8-fold (0.44 log units) below what was measured; measured number above the stated range.
By their numbers in this assay, from the lowest: compounds 1, 2 and 3 (each within the scatter of the next); then compound 4.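

For the compounds shown here, the position tolerates methyl, tert-butyl and (dimethylamino)methyl on the carbonyl carbon alike, but not every group: in this assay 4-(dimethylamino)phenyl gives the first steps beyond the scatter, with a 2.7-fold higher number from compound 3 to compound 4 (0.43 log units; beyond the scatter) and a 3.1-fold higher number from compound 2 to compound 4 (0.49 log units; beyond the scatter) and also a 3.3-fold higher number from compound 1 to compound 4 (0.52 log units; beyond the scatter) as modest rises in the compound needed. Compound 3 and compound 4 both carry dimethylamino, so the step between them marks the entry of the six-membered aromatic ring in place of the chain carbon rather than the gain of an amine. No measurement shown explains the rise.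

With one ring-bearing compound, the effect of the ring itself cannot be separated from that of its dimethylamino substituent, and unsubstituted phenyl would address this. Cyclohexyl, a saturated ring, would show whether an aromatic ring is required for the rise.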